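Methoxy in place of acetoxy on a side chain

The source may report more compounds than this note shows. Statements on the series, on what has been measured and on what is new or still open speak of the compounds shown alone.

Measured so far:
compound 1 `C[C@@H](O)Cc1cc(-c2ccnc3[nH]nc(C(F)(F)F)c23)cc(C2(C#N)CC2)c1`, 34 nM
compound 2 `CC(=O)OCCc1cc(-c2ccnc3[nH]nc(C(F)(F)F)c23)cc(C2(C#N)CC2)c1`, 119 nM

Both compounds were tested in an assay on isolated protein for inhibition of protein kinase C epsilon type (Homo sapiens), read by coupled enzyme assay; a higher number here means a weaker inhibitor, a lower number a stronger inhibitor. Compound 1 gives 34 nM, and compound 2 gives 119 nM, the higher of the two numbers, so compound 2 is the weaker inhibitor of the pair. Among the compounds with values here, the single step between them, a 3.5-fold higher number from compound 1 to compound 2 (0.54 log units; beyond the scatter), arose from acetoxymethyl in place of 1-hydroxyethyl on a saturated chain carbon bound to an aromatic carbon.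

Compound 3 `COCCc1cc(-c2ccnc3[nH]nc(C(F)(F)F)c23)cc(C2(C#N)CC2)c1` has not yet been measured in this assay. It differs from compound 2 by methyl in place of acetyl on an oxygen on a saturated carbon. Within the data shown here, only the one measured step bears on this change, and it concerns a different part of the chain, so it gives limited guidance. Since compound 2 shows 119 nM and the acetyl is merely trimmed to a methyl, compound 3 is expected to lie near compound 2, perhaps a little lower, a step of about a 1.5-fold lower number from compound 2 to compound 3 (0.17 log units; within the scatter). The estimate for compound 3 is 80 nM, within 30 nM to 220 nM.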

Compound 3, inhibition constant: 145 nM
Compound 3: middle estimate off by 1.8-fold (0.26 log units), on the low side; the measured number falls inside the stated range.
By their numbers in this assay, from the lowest: compound 1; then compounds 2 and 3 (each within the scatter of the next).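

In this assay, the oxygen on the chain carries either acetyl or methyl with a 1.2-fold higher number from compound 2 to compound 3 (0.09 log units; within the scatter), so trimming acetyl to methyl, which removes its carbonyl, gives numbers that cannot be told apart. The wider gap remains with the other comparison, a 4.3-fold higher number from compound 1 to compound 3 (0.63 log units; beyond the scatter), which places compound 3 on the same side of compound 1 as compound 2. No measurement shown here explains either step.

The change from compound 1 to compound 3 alters both the hydroxyl and the shape of the chain, so the data cannot say which of the two accounts for the lower number of compound 1; a 2-hydroxyethyl chain would separate them. On these data alone, how an amine, a carboxylic acid or a longer chain at this position would read also remains open.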